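Trifluoromethyl for Phenyl: What Compound 3 Might Show

The compounds below may be only part of what the source reports. "The series", "measured", "known", "first", "only" and "open" are said of these compounds alone.

Measured so far:
compound 1, `c1ccc(-c2nnc(-c3c[nH]c4ccccc34)o2)cc1`: in a functional assay on PC-3 cells (Homo sapiens) for cytotoxicity, read by MTT assay (on this read-out lower numbers stand for stronger inhibition and higher numbers for weaker inhibition), compound 1 gives > 1000000 nM, which is a limit of the assay and not a number.
compound 2, `COc1cc(-c2nnc(-c3c[nH]c4ccccc34)o2)ccc1O`: in this assay compound 2 gives > 1000000 nM, likewise a limit.

Compound 1 stands at the limit of > 1000000 nM in this assay, at which 2 of the 2 values shown sit. Both values shown are limits. No order between compound 1 and compound 2 can be read from them, and neither gives a number to build on.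

Compound 3, `FC(F)(F)c1nnc(-c2c[nH]c3ccccc23)o1`, differs from compound 1 in one place: trifluoromethyl in place of phenyl on an aromatic carbon. Among the measured compounds shown here, no step between measured compounds covers a change of this kind, and the two limits give no direction for it. In this assay a number no higher from compound 1 to compound 3 (the limit leaves the size open) is therefore expected to amount to no movement beyond the usual scatter. Compound 3 is estimated at 1000000 nM, with a range from 300000 nM to 3000000 nM, and is expected most likely to be reported again only as a limit.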

Compound 3, half-maximal inhibitory concentration: > 1000000 nM
Compound 3: a limit, no number (the forecaster's own chance of this, stated with the estimate: 85%); the middle value lies on the limit itself.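

Compound 1 and compound 3 both stand only as limits in this assay, and no step can be read between them. The compounds shown leave open whether any change on the shared core gives a measurable value, and whether trifluoromethyl and phenyl differ at all.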